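Removing the Amide Acyl Group from a Trimethoxyanilide

The source may report more compounds than this note shows. Statements on the series, on what has been measured and on what is new or still open speak of the compounds shown alone.

Measured compounds:
compound 1 `COc1ccc(CNc2cc(OC)c(OC)c(OC)c2)cc1F` — 32200 nM
compound 2 `C/C=C/C(=O)N(Cc1ccc(OC)cc1)c1cc(OC)c(OC)c(OC)c1` — 500 nM
compound 3 `C/C=C/C(=O)N(Cc1ccc(OC)c(F)c1)c1cc(OC)c(OC)c(OC)c1` — 1160 nM

Three compounds were tested in a functional assay on HCT-116 cells (Homo sapiens) for inhibition, read by MTT assay, with a stated time of 48 h; on this read-out higher numbers stand for weaker inhibition and lower numbers for stronger inhibition. Compound 2 gave 500 nM, the lowest number of the three. Compound 3 gave 1160 nM, and compound 1 gave 32200 nM. The steps between them are of two kinds. From compound 2 to compound 3 the change is hydrogen in place of fluoro on an aromatic carbon read in reverse, and the step was a 2.3-fold higher number from compound 2 to compound 3 (0.37 log units; beyond the scatter). From compound 3 to compound 1 the change is hydrogen in place of (prop-1-en-1-yl)carbonyl on a nitrogen on an aromatic ring, and the step was a 28-fold higher number from compound 3 to compound 1 (1.44 log units; beyond the scatter).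

Compound 4 `COc1ccc(CNc2cc(OC)c(OC)c(OC)c2)cc1` is not yet measured. It differs from compound 2 by hydrogen in place of (prop-1-en-1-yl)carbonyl on a nitrogen on an aromatic ring, the same change that was made from compound 3 to compound 1, at a place described in the same words for both pairs. The two cores differ as set out by hydrogen in place of fluoro on an aromatic carbon.

Within the data shown here, for compound 4 in this assay the expected step is a 28-fold higher number from compound 2 to compound 4 (1.45 log units; beyond the scatter), about the same size as the earlier instance of this change, since that earlier step, a 28-fold higher number from compound 3 to compound 1 (1.44 log units; beyond the scatter), is the only instance of this change seen here. On that basis compound 4 is estimated at 14000 nM, with a likely range from 5000 nM to 40000 nM.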

Compound 4, half-maximal inhibitory concentration: 18400 nM
Beside the measured number, compound 4's estimate is 1.3-fold (0.12 log units) below it; the range from low to high includes it.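

Removing the (prop-1-en-1-yl)carbonyl group from the nitrogen carried over from the fluoro-bearing core to the core without fluoro in this assay, where it gave a 37-fold higher number from compound 2 to compound 4 (1.57 log units; beyond the scatter), and the two instances agree: the same change on two cores in this assay, a 28-fold higher number (1.44 log units; beyond the scatter) from compound 3 to compound 1 and a 37-fold higher number (1.57 log units; beyond the scatter) from compound 2 to compound 4, 1.3-fold (0.12 log units) apart, within the scatter of two such steps. Between the two compounds without the acyl group, the exchange of fluoro for hydrogen gave a 1.8-fold lower number from compound 1 to compound 4 (0.24 log units; within the scatter), and the size of this change does not differ measurably from that seen between the two acylated compounds: the same change on two cores in this assay, a 2.3-fold higher number (0.37 log units; beyond the scatter) from compound 2 to compound 3 and a 1.8-fold higher number (0.24 log units; within the scatter) from compound 4 to compound 1, 1.3-fold (0.12 log units) apart, within the scatter of two such steps. Together these steps show that, across these four compounds, the loss on removing the acyl group was much the same with or without the fluoro, but the two cores differ only at that one place, so they do not show that the step would hold on a core altered elsewhere, nor why the acyl group matters.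

The compounds shown leave open whether the double bond of the (prop-1-en-1-yl)carbonyl group is needed, which a saturated butanoyl group or a shorter acetyl group on the same nitrogen would test. They also leave open whether a chloro or a methyl group in place of the fluoro would carry the removal step equally well.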